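The source may hold more compounds than are shown below. What is called first, only, known or untested is meant among the compounds shown, and "the series" means these compounds.

Measured in a functional assay on MCF7 cells (Homo sapiens) for cytotoxicity, read by MTT assay, with a stated time of 24 h; on this read-out lower numbers stand for stronger inhibition and higher numbers for weaker inhibition:
Compound 1 `CCNc1cc(-c2ccc(NC(=O)Nc3ccccc3Cl)cc2C)ccn1`: 8350 nM
Compound 2 `CCNc1cc(-c2ccc(NC(=O)Nc3cccc4ccccc34)cc2C(F)(F)F)ccn1`: 16300 nM

Compound 2, at 16300 nM, cannot be told apart from compound 1, at 8350 nM. Their two numbers lie within the usual scatter of such measurements. Compound 3 `CCNc1cc(-c2ccc(NC(=O)Nc3ccccc3Cl)cc2C(F)(F)F)ccn1` has 2-chlorophenyl in place of naphthalen-1-yl on an amide-type nitrogen of compound 2: 2-chlorophenyl in place of naphthalen-1-yl on an amide-type nitrogen. Among the compounds with values here, no measured pair shows this change alone. The 2-chlorophenyl group also occurs in compound 1, at 8350 nM, so no step beyond the scatter is expected in this assay. The expected step is a 1.5-fold lower number from compound 2 to compound 3 (0.17 log units; within the scatter). For compound 3 the estimate is 11000 nM, with an expected range from 5000 nM to 25000 nM.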

Compound 3, half-maximal inhibitory concentration: 3680 nM
Estimate against measurement, compound 3: 3.0-fold (0.48 log units) above; measured number below the stated range.
By their numbers in this assay, from the lowest: compound 3; then compounds 1 and 2 (each within the scatter of the next).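

In this assay, 2-chlorophenyl in place of naphthalen-1-yl on an amide-type nitrogen gives a 4.4-fold lower number from compound 2 to compound 3 (0.65 log units; beyond the scatter) with trifluoromethyl held fixed, so the group on this nitrogen alone moves the read-out. Trifluoromethyl in place of methyl on an aromatic carbon gives a 2.3-fold lower number from compound 1 to compound 3 (0.36 log units; beyond the scatter) with 2-chlorophenyl held fixed, and this change could not be read alone before. No measurement here explains either step. Going by these compounds, whether a plain phenyl or a 2-fluorophenyl on that nitrogen would give a similar number remains open. So does the effect of a chlorine or a methoxy group in place of trifluoromethyl.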